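This account rests on a few compounds, and the source may have more. Where it says the series, first, only, none or still open, it means among the compounds named here.

Three dithiocarbamate esters built on a shared core have been tested in a functional assay on MDA-MB-435S cells (Homo sapiens) for antiproliferative activity, read by MTT assay, with a stated time of 72 h; on this read-out lower numbers stand for stronger inhibition and higher numbers for weaker inhibition. Compound 1 `O=c1cc(CSC(=S)N2CCCC2)oc2ccccc12` reaches only the limit of > 30000 nM there. Compound 2 `CC(C)N(C(=S)SCc1oc2ccccc2c(=O)c1Cl)C(C)C` gives 23600 nM in this assay. Compound 3 `COc1ccc2oc(CSC(=S)N(C(C)C)C(C)C)cc(=O)c2c1` gives 22100 nM in this assay, a number within the scatter of that for compound 2, so the two cannot be told apart. The only other result, that of compound 1, is a limit (the limit of > 30000 nM in this assay, at which 1 of the 3 values shown sits). Compound 4 `CC(C)N(C(=S)SCc1cc(=O)c2ccccc2o1)C(C)C` differs from compound 3 by hydrogen in place of methoxy on an aromatic carbon. Among the compounds with values here, no measured pair shows this change, so a step within the scatter is expected, with some chance of a limit. Compound 4 is thus expected to give 26000 nM, between 12000 nM and 55000 nM, an expected step of a 1.2-fold higher number from compound 3 to compound 4 (0.07 log units; within the scatter).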

Compound 4, half-maximal inhibitory concentration: > 40000 nM
Compound 4: no number, only a limit (the forecaster's own chance of this, stated with the estimate: 40%); middle value at least 1.5-fold (0.18 log units) away from the limit.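

Compound 4 sits at a limit of the assay: the limit of > 40000 nM in this assay, at which 1 of the 4 values shown sits. Hydrogen in place of methoxy gives an at least 1.8-fold higher number from compound 3 to compound 4 (0.25 log units; that floor lies within the scatter), and hydrogen in place of chloro gives an at least 1.6-fold higher number from compound 2 to compound 4 (0.22 log units; that floor lies within the scatter), so these are the first steps that touch these substituents, though each shows only a floor and not a full size; the step between the two limits of compound 1 and compound 4 cannot be read. Neither step therefore shows that losing the methoxy or the chloro matters. Still open, as far as these compounds go, is how an amine or an ethoxy group on that same aromatic carbon would read in this assay.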